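This account rests on a few compounds, and the source may have more. Where it says the series, first, only, none or still open, it means among the compounds named here.

In a functional assay on DLD-1 cells (Homo sapiens) for cytotoxicity, with a stated time of 48 h (on this read-out higher numbers stand for weaker inhibition and lower numbers for stronger inhibition), compound 1 (`CC(C)COc1ccc2oc(/C=C/[S+](C)[O-])cc(=O)c2c1`) gives 5000 nM and compound 3 (`Cc1cccc2oc(/C=C/[S+](C)[O-])cc(=O)c12`) gives 5500 nM as two values within the usual scatter of each other. Compound 2 (`COc1cccc2oc(/C=C/[S+](C)[O-])cc(=O)c12`) gives > 10000 nM as a limit of the assay and not a number. Among the measured compounds shown here, the only measured step is an at least 1.8-fold lower number from compound 2 to compound 3 (0.25 log units; that floor lies within the scatter) with methyl in place of methoxy on an aromatic carbon.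

Compound 4 (`CC(C)CCOc1ccc2oc(/C=C/[S+](C)[O-])cc(=O)c2c1`) keeps the core of compound 1 and differs in its chain (isobutyl in place of isopropyl on a saturated chain carbon bound to an oxygen on an aromatic ring) with isobutyl in place of isopropyl on a saturated chain carbon bound to an oxygen on an aromatic ring, which also reads isobutoxy to isopentyloxy. For the measured compounds named here, the one measured step sits on a different group, and no measured pair changes this chain, so it offers little guidance here. With compound 1 at 5000 nM as the starting point, no step beyond the scatter is expected in this assay in either direction. The expected outcome is no change at the digits printed from compound 1 to compound 4 (within the scatter) as an estimate only. For compound 4 the expected value is 5000 nM with an estimated range from 2000 nM to 10000 nM for the measurement to test.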

Compound 4, half-maximal inhibitory concentration: 4100 nM
Beside the measured number, compound 4's estimate is 1.2-fold (0.09 log units) above it; the range from low to high includes it.
By their numbers in this assay, from the lowest: compounds 4, 1 and 3 (each within the scatter of the next). At a limit, above all of these: compound 2.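

Among the compounds shown here, this is the first measured pair in which only this chain changes. Going from isobutoxy to isopentyloxy in this assay gives a 1.2-fold lower number from compound 1 to compound 4 (0.09 log units; within the scatter), so the two compounds cannot be told apart and the added carbon has no readable effect on the number. The measured values give no reason why this chain change leaves the two compounds within the scatter of each other.

For the compounds shown here, one pair shows only that this single swap makes no readable difference, and it says nothing about chains that differ more from these two. A much longer chain, a phenyl ring, an amine or a carboxylic acid in place of the isobutyl group could give a different result, and the compounds shown do not settle this.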